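This account rests on a few compounds, and the source may have more. Where it says the series, first, only, none or still open, it means among the compounds named here.

Working notes on the pyrazole substituent series sharing the aminopyrimidine-carbonitrile core.

Compound 1 `Cc1c(Nc2nc(N)c3c(C#N)c(N4CCC[C@H]4C)n(C)c3n2)cnn1[C@H]1CCOC1` carries an oxolan-3-yl group on the pyrazole nitrogen and gives 51 nM in an assay on HEK293 cells for inhibition of Leucine-rich repeat serine/threonine-protein kinase 2 variant G2019S (Homo sapiens), with a stated time of 48 h; on this read-out higher numbers stand for weaker inhibition and lower numbers for stronger inhibition. Compound 2 `Cc1c(Nc2nc(N)c3c(C#N)c(N4CCC[C@H]4C)n(C)c3n2)cnn1C1COC1` bears oxetan-3-yl at the same position and gives 190 nM in this assay; the step is a 3.7-fold higher number from compound 1 to compound 2 (0.57 log units; beyond the scatter). Compound 3 `Cc1c(Nc2nc(N)c3c(C#N)c(N4CCC[C@H]4C)n(C)c3n2)cnn1CC(C)(C)O` bears the open-chain 2-hydroxy-2-methylpropyl group and gives 120 nM in this assay. For the measured compounds named here, compound 3 sits second highest of the three numbers so far: against compound 2 the step is a 1.6-fold lower number from compound 2 to compound 3 (0.20 log units; within the scatter), while from the oxolane the step is a 2.4-fold higher number from compound 1 to compound 3 (0.37 log units; beyond the scatter).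

Compound 4 `Cc1c(Nc2nc(N)c3c(C#N)c(N4CCC[C@H]4C)n(C)c3n2)cnn1[C@@H]1CCOC1` is the next entry. The change from compound 3 is oxolan-3-yl in place of 2-hydroxy-2-methylpropyl on an aromatic nitrogen; compound 4 is the enantiomer of compound 1 at the oxolane stereocentre. The step that bears on it directly is the reverse of a 2.4-fold higher number from compound 1 to compound 3 (0.37 log units; beyond the scatter), a modest gain on returning to the oxolane, but that step was measured for the other stereocentre configuration, and nothing in the measured set shows how much the configuration matters. Provisionally the oxolane gain is expected to carry over, with the stereochemistry widening the uncertainty rather than setting its direction. The expected step is a 1.6-fold lower number from compound 3 to compound 4 (0.20 log units; within the scatter), a modest lowering. Compound 4 is therefore estimated at 75 nM, with a range of 30 nM to 220 nM.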

Compound 4, half-maximal inhibitory concentration: 80 nM
Compound 4: middle estimate off by 1.1-fold (0.03 log units), on the low side; the measured number falls inside the stated range.
By their numbers in this assay, from the lowest: compounds 1, 4, 3 and 2 (each within the scatter of the next, the first and the last beyond it).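

In this assay the oxolan-3-yl group can now be read in both configurations, and the step of a 1.6-fold higher number from compound 1 to compound 4 (0.20 log units; within the scatter) lies within the scatter, so the two enantiomers cannot be told apart at this position on this read-out, a comparison that isolates the stereocentre alone: the fact that compounds 1 and 4 differ only in the configuration as drawn.

Oxolan-3-yl in the configuration of compound 4 also gives a lower number than oxetan-3-yl with the step of a 2.4-fold lower number from compound 2 to compound 4 (0.38 log units; beyond the scatter), in the same direction as the reverse of a 3.7-fold higher number from compound 1 to compound 2 (0.57 log units; beyond the scatter), so for these compounds the oxolane and oxetane groups stay separated in either configuration. The separation from 2-hydroxy-2-methylpropyl is less secure: a 1.5-fold lower number from compound 3 to compound 4 (0.18 log units; within the scatter) lies within the scatter, whereas a 2.4-fold higher number from compound 1 to compound 3 (0.37 log units; beyond the scatter) lies beyond it, so only compound 1 separates from the open-chain group.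

The compounds shown leave open whether a six-membered ring such as oxan-4-yl, or a basic amine such as piperidin-4-yl, would continue the trend from oxetan-3-yl to oxolan-3-yl on this aromatic nitrogen. They also leave open how a longer hydroxyalkyl chain or a carboxylic acid would compare with 2-hydroxy-2-methylpropyl.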